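Shortening the Acid Chain from Compound 3 to Compound 4

The source may report more compounds than this note shows. Statements on the series, on what has been measured and on what is new or still open speak of the compounds shown alone.

Three compounds have so far been measured in an assay for inhibition of histone acetyltransferase KAT2B (Homo sapiens), read by TR-FRET, with a stated time of 10 min, tested at 50 uM; a lower number here means less inhibition, a higher number more inhibition at the concentration tested (going by the name of the read-out):

- compound 1 `Cc1cccc(NC(=O)CN2C(=O)/C(=C3\SC(=S)N(CCS(=O)(=O)O)C3=O)c3ccccc32)c1`: 6%
- compound 2 `Cc1ccc(CN2C(=O)/C(=C3\SC(=S)N(CCS(=O)(=O)O)C3=O)c3ccccc32)cc1`: a limit of the assay, < 5%
- compound 3 `O=C(O)CCCCCN1C(=O)/C(=C2/C(=O)Nc3ccccc32)SC1=S`: 9%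

Compound 3 and compound 1 give the two actual numbers, and they lie within the usual scatter of each other, so neither can be called the stronger. Compound 2 sits at the limit described by the limit of < 5% in this assay, at which 1 of the 3 values shown sits.

Compound 4 `O=C1Nc2ccccc2/C1=C1/SC(=S)N(CCS(=O)(=O)O)C1=O` differs from compound 3 in one place: sulfo in place of 3-carboxypropyl on a saturated chain carbon, two bonds along the chain from an amide-type nitrogen in a ring. Within the data shown here, the only measured step, a number at least 1 percentage points lower from compound 1 to compound 2 (that floor lies within the scatter), concerns a different position on the core and did not move beyond the scatter, so no measured step bears directly on this change. With the shared core kept and only the acid chain altered, the expectation is a step of a number 2 percentage points lower from compound 3 to compound 4 (within the scatter), that is, none beyond the scatter. Compound 4 is therefore estimated at 7%, with a range from 0% to 18% in this assay.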

Compound 4, a percentage reported as inhibition, at one concentration (the size of the read-out at that concentration, not a potency): < 5%
Compound 4: a limit, no number; the forecaster's own chance of this, stated with the estimate: 35%; middle value at least 2 percentage points away from the limit.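

In this assay, compound 4 gives a limit of the assay rather than a number, and this limit recurs in the series: the limit of < 5% in this assay, at which 2 of the 4 values shown sit. Placing sulfo where 3-carboxypropyl stood gives a number at least 4 percentage points lower from compound 3 to compound 4 (that floor lies within the scatter), and placing hydrogen where ((3-methylphenyl)carbamoyl)methyl stood on the amide-type nitrogen in a ring gives a number at least 1 percentage points lower from compound 1 to compound 4 (that floor lies within the scatter). Neither step shows a change beyond the scatter, and the step involving the two limits cannot be read.

As far as these compounds go, the change from compound 3 to compound 4 alters the acid and the chain length together, so the effect of each remains unknown. A 2-carboxyethyl chain would pair the carboxylic acid with the shorter chain, while a chain ending in an amine would show what happens without an acid at this position.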